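The source may hold more compounds than are shown below. What is called first, only, known or untested is meant among the compounds shown, and "the series" means these compounds.

Of the compounds shown here, three have been read so far in a functional assay on MDA-MB-435 cells (Homo sapiens); on this read-out lower numbers stand for stronger inhibition of growth and higher numbers for weaker inhibition of growth. Compound 1 `Oc1cc(-c2ccc(Cl)cc2)nc2ncccc12` gives 5890 nM, and compound 2 `COc1ccccc1-c1cc(O)c2ccc(C)nc2n1` gives 21900 nM. Compound 3 `COc1cccc(-c2cc(O)c3cc(C)cnc3n2)c1` is recorded only as a limit, < 10 nM. Among the three, only compound 3 sits at the limit of < 10 nM in this assay, at which 1 of the 3 values shown sits.

The next compound to read is compound 4 `COc1cccc(-c2cc(O)c3cccnc3n2)c1`, which differs from compound 3 in one place: hydrogen in place of methyl on an aromatic carbon. This is hydrogen in place of methyl on an aromatic carbon, and the rest of the structure is unchanged.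

Among the compounds with values here, no measured pair isolates this change, so the size of the step in this assay has to be judged indirectly. Compound 1, which also has no methyl on that carbon, gives 5890 nM, but it differs elsewhere as well and so suggests only a direction. A clear step beyond the scatter is expected, towards weaker inhibition of growth, though it should stop well short of the weak end of the series. The estimated step is an at least 20-fold higher number from compound 3 to compound 4 (1.30 log units; beyond the scatter). For compound 4 the expected value is 200 nM, with an estimated range of 20 nM to 2500 nM.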

Compound 4, concentration for 50% growth inhibition: < 10 nM
Compound 4: a limit, no number (the forecaster's own chance of this, stated with the estimate: 15%); middle value at least 20-fold (1.30 log units) away from the limit.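

Compound 3 and compound 4 are both recorded only as limits in this assay, so no step can be read between them: the limit of < 10 nM in this assay, at which 2 of the 4 values shown sit.

The compounds shown leave open whether hydrogen in place of methyl on an aromatic carbon changes growth inhibition at all, and how large any such change would be.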